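The source may report more compounds than this note shows. Statements on the series, on what has been measured and on what is new or still open speak of the compounds shown alone.

- compound 1 `CC[C@@H]1c2cc(Cl)ccc2C(=O)N1c1cncc2c1CCC[C@H]2NC(C)=O` gives < 3.5 mL/min/kg (a limit)
- compound 2 `CC(=O)N[C@@H]1CCCc2c1cncc2N1C(=O)c2ccc(Cl)cc2[C@H]1C` gives < 3.5 mL/min/kg (a limit)
- compound 3 `CC(=O)N[C@@H]1CCCc2c1cncc2N1Cc2cc(Cl)ccc2C1=O` gives < 3.5 mL/min/kg (a limit)

In an ADME assay on microsomes from liver (Homo sapiens) for metabolic stability, read by LC-MS, using NADPH, with stated times of 10 min and 30 min (a lower number here means slower removal, a higher number faster removal of the compound), compound 1 gives < 3.5 mL/min/kg as a limit of the assay and not a number. The whole set offers only the limit of < 3.5 mL/min/kg in this assay, at which 3 of the 3 values shown sit, as its reading. Compound 4 `CCC(=O)N[C@@H]1CCCc2c1cncc2N1C(=O)c2ccc(Cl)cc2[C@H]1CC` differs from compound 1 at one place, where acetamido becomes propanoylamino (methyl in place of hydrogen on a saturated chain carbon bound to a carbonyl carbon). The measured steps (a step that the two limits leave unreadable from compound 1 to compound 2 and a step that the two limits leave unreadable from compound 1 to compound 3 and a step that the two limits leave unreadable from compound 2 to compound 3) have no readable size and all keep the acetamido group, so they give no guide to this change. The expectation therefore starts from compound 1 at its limit of < 3.5 mL/min/kg as the only anchor. The estimated step is a number no lower from compound 1 to compound 4 (the limit leaves the size open) and no move beyond the usual scatter is expected. Compound 4 is expected at 3.5 mL/min/kg with 2.5 mL/min/kg to 7 mL/min/kg as the estimated range.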

Compound 4, clearance: < 3.5 mL/min/kg
Compound 4 was reported as a limit (the forecaster's own chance of this, stated with the estimate: 65%); the middle value sits exactly at the limit.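

Compound 1 and compound 4 are both reported only as a limit of the assay and not as a number, so no step can be read between them. The compounds shown leave open how acetamido and propanoylamino compare in this assay.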